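Hydrogen to 4-fluorophenyl on the fused five-membered ring

The source may report more compounds than this note shows. Statements on the series, on what has been measured and on what is new or still open speak of the compounds shown alone.

Measured compounds:
Compound 1, `O=S(=O)(Nc1ccc(F)c(C#Cc2cnc3[nH]ncc3c2)c1F)c1cccnc1`: 445 nM
Compound 2, `COc1n[nH]c2ncc(C#Cc3c(F)ccc(NS(=O)(=O)c4cccnc4)c3F)cc12`: 89 nM
Compound 3, `O=S(=O)(Nc1ccc(F)c(C#Cc2cnc3[nH]nc(-c4ccncc4)c3c2)c1F)c1cccnc1`: 78 nM

All three were measured in a functional assay on COLO 205 cells (Homo sapiens) for antiproliferative activity, read by MTT assay, with a stated time of 68 h; a higher number here means a weaker inhibitor, a lower number a stronger inhibitor. Compound 1 gives the highest of the three numbers; compound 2 and compound 3 both sit well below it, and their own pair differs only within the scatter (a 1.1-fold lower number from compound 2 to compound 3 (0.06 log units; within the scatter)).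

Compound 4 is `O=S(=O)(Nc1ccc(F)c(C#Cc2cnc3[nH]nc(-c4ccc(F)cc4)c3c2)c1F)c1cccnc1`. Relative to compound 1 the change is 4-fluorophenyl in place of hydrogen on an aromatic carbon.

Going by the values given here, two measured steps bear on this: a 5.0-fold lower number from compound 1 to compound 2 (0.70 log units; beyond the scatter) and a 5.7-fold lower number from compound 1 to compound 3 (0.76 log units; beyond the scatter). Both replace the same hydrogen on the shared core, and both lower the number by a modest, clearly resolved amount regardless of whether the entering group is methoxy or pyridin-4-yl. The 4-fluorophenyl group in compound 4 is, like pyridin-4-yl, a six-membered aromatic ring, so a lowering of similar size is expected here, not a step larger than those seen.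

Compound 4 is therefore estimated at 85 nM, with a range from 30 nM to 250 nM. The expected step is a 5.2-fold lower number from compound 1 to compound 4 (0.72 log units; beyond the scatter).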

Compound 4, half-maximal inhibitory concentration: 166 nM
Compound 4: middle estimate off by 2.0-fold (0.29 log units), on the low side, within the range that was stated.
By their numbers in this assay, from the lowest: compounds 3, 2 and 4 (each within the scatter of the next, the first and the last beyond it); then compound 1.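

In this assay, the step of a 2.7-fold lower number from compound 1 to compound 4 (0.43 log units; beyond the scatter) shows that a six-membered aromatic ring of carbon only also lowers the number at this aromatic carbon of the five-membered ring, so the lowering is not confined to methoxy and pyridin-4-yl. The ring itself matters, since the change to 4-fluorophenyl from pyridin-4-yl gives a 2.1-fold higher number from compound 3 to compound 4 (0.33 log units; beyond the scatter) and the two aromatic rings do not read as equivalent, whereas the change from methoxy gives a 1.9-fold higher number from compound 2 to compound 4 (0.27 log units; within the scatter) and leaves those two compounds unresolved. Nothing available explains why these groups differ.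

From the compounds shown here alone, whether an unsubstituted phenyl would read with compound 3 or with compound 4 remains open, so the share of the fluorine in this result is unknown. Also open, going by these compounds, is whether an amine or a carboxylic acid on this carbon would lower the number as well.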